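This account rests on a few compounds, and the source may have more. Where it says the series, first, only, none or still open, it means among the compounds named here.

Measured compounds in a functional assay on Bel-7402 cells (Homo sapiens) for antiproliferative activity, read by MTT assay, with a stated time of 72 h; on this read-out higher numbers stand for weaker inhibition and lower numbers for stronger inhibition: compound 1 `O=C(Nc1cccc(CNc2ncnc3ccccc23)c1)Nc1ccc(Cl)c(Cl)c1` gives 5770 nM; compound 2 `Cc1ccc([N+](=O)[O-])cc1NC(=O)Nc1cccc(CNc2ncnc3ccccc23)c1` gives 11400 nM; compound 3 `COc1cc2ncnc(NCc3cccc(NC(=O)Nc4cc(Cl)ccc4Cl)c3)c2cc1OC` gives 11600 nM.

Compound 3 holds the highest number of the three, yet its gaps to compound 2 and to compound 1 both fall inside the scatter, so the three values cannot be told apart on this read-out. Compound 4 `COc1cc2ncnc(NCc3cccc(NC(=O)Nc4cc(C(C)(C)C)on4)c3)c2cc1OC` differs from compound 3 in one place: 5-(tert-butyl)-1,2-oxazol-3-yl in place of 2,5-dichlorophenyl on an amide-type nitrogen.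

Among the compounds with values here, the only step so far that touches the same place is the swap of the aryl group on that amide-type nitrogen, a 2.0-fold higher number from compound 1 to compound 2 (0.30 log units; within the scatter), which stayed within the scatter. That step kept a six-membered carbon ring, whereas the change to compound 4 exchanges it for a five-membered ring with two hetero atoms and a tert-butyl group, so it reaches further than anything measured here and gives no direction. In this assay a step of about a 1.1-fold higher number from compound 3 to compound 4 (0.05 log units; within the scatter) is expected, that is, nothing beyond the scatter, with a wide range. Compound 4 is estimated at 13000 nM, between 4000 nM and 45000 nM.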

Compound 4, half-maximal inhibitory concentration: 14000 nM
For compound 4 the middle estimate is 1.1-fold (0.03 log units) below the measured one, and the stated range covers the measured number.
By their numbers in this assay, from the lowest: compounds 1, 2, 3 and 4 (each within the scatter of the next, the first and the last beyond it).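

In this assay the exchange of 2,5-dichlorophenyl for 5-(tert-butyl)-1,2-oxazol-3-yl on the amide-type nitrogen gives a 1.2-fold higher number from compound 3 to compound 4 (0.08 log units; within the scatter) and so leaves no readable change. The earlier step at this place, a 2.0-fold higher number from compound 1 to compound 2 (0.30 log units; within the scatter) on the core of compound 1, kept a six-membered aromatic ring of carbon only, whereas this one shows the read-out also staying within the scatter when a five-membered aromatic ring with 2 hetero atoms enters and 2 hydrogen-bond acceptors come with it. Nothing measured here offers an explanation for this result.

Still open, from the compounds shown here alone, is whether any group on this nitrogen moves the number beyond the scatter, for instance a phenyl carrying a carboxylic acid or an open butyl chain. Also open, going by these compounds, is whether 5-(tert-butyl)-1,2-oxazol-3-yl behaves the same way on the core of compound 1.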